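The source may hold more compounds than are shown below. What is called first, only, known or untested is meant among the compounds shown, and "the series" means these compounds.

In a functional assay on RKE cells for antagonist activity at Vasoactive intestinal polypeptide receptor 1 (Rattus norvegicus), read by HTRF and cAMP accumulation, with stated times of 10 min and 30 min (on this read-out higher numbers stand for weaker inhibition and lower numbers for stronger inhibition), three compounds have been measured so far. Compound 1 `CC(C)c1cc(C(C)(C)C)cc(-c2ccc(F)cc2)c1CO` gives 740 nM. Compound 2 `CC(C)CC(=O)Nc1sc2c(c1C#N)CCCC2` gives 1900 nM, and compound 3 `N#Cc1c(NC(=O)CCc2ccccc2)sc2c1CCCC2` gives 290 nM. Compounds 2 and 3 share the same core and differ only in the chain on the amide, where a 6.6-fold lower number from compound 2 to compound 3 (0.82 log units; beyond the scatter). Compound 3 thus holds the lowest number of the three, with compound 1 next and compound 2 furthest away, both gaps beyond the scatter.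

Compound 4 `N#Cc1c(NC(=O)CCc2ccc(Cl)cc2)sc2c1CCCC2` keeps the core and chain of compound 3 and differs only by chloro in place of hydrogen on an aromatic carbon. Within the data shown here, no measured step makes this kind of change; the single step on this chain, a 6.6-fold lower number from compound 2 to compound 3 (0.82 log units; beyond the scatter), replaced one group with another of a different sort, so it gives little guide to a single substituent on the ring. Among the measured compounds shown here, with no comparable precedent, the step is expected to stay within the usual scatter: a 1.2-fold lower number from compound 3 to compound 4 (0.06 log units; within the scatter) is the estimate. Compound 4 is therefore expected to give about 250 nM in this assay, with a range from 90 nM to 700 nM.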

Compound 4, half-maximal inhibitory concentration: 1200 nM
Estimate against measurement, compound 4: 4.8-fold (0.68 log units) below, outside the stated range (above it).
By their numbers in this assay, from the lowest: compound 3; then compounds 1, 4 and 2 (each within the scatter of the next, the first and the last beyond it).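

In this assay, the ring at the end of the amide chain of compound 3 does not tolerate every change: phenyl to 4-chlorophenyl gives a 4.1-fold higher number from compound 3 to compound 4 (0.62 log units; beyond the scatter) and so shows that one chlorine atom on an aromatic carbon, para to a large group, is enough to move the number beyond the scatter. Among these compounds, the earlier step, a 6.6-fold lower number from compound 2 to compound 3 (0.82 log units; beyond the scatter) on the same chain, showed only that the group at this end of the chain matters, and this result extends that sensitivity to a single substituent on the ring, with the number now moving upward. No measurement given here bears on what lies behind this rise.

It remains open whether the rise belongs to chloro in particular or to any group at this ring carbon, since only hydrogen and chloro are shown there, and a fluoro, a methoxy or an amine in the same place could separate the two readings. From the compounds shown here alone, it is equally open whether chloro on another carbon of the ring, or a longer chain carrying the same 4-chlorophenyl, would give the same result.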